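Chain homologation on the amide nitrogen and half-life

A few compounds are considered here, and "the series" means these few. Any claim that something is new, unique, unknown or untested is made for them only; others in the source may bear on it.

Compound 2 `Cc1c(Oc2cnc(C(=O)NC(C)CO)cn2)ccc2c1B(O)OC2` is the starting point of this step. In an ADME assay on the whole organism (strain CD1) for metabolic stability, with Mus musculus as the target, read by LC-MS, at a dose of 5 mg/kg by the oral route (on this read-out higher numbers stand for a longer-lived compound and lower numbers for a shorter-lived compound), compound 2 gives 2.7 h. Its only comparator, compound 1 `Cc1c(Oc2cnc(C(=O)NCCO)cn2)ccc2c1B(O)OC2`, gives 3 h in this assay; the two numbers lie within the scatter of each other, so compound 2 and compound 1 stand as one on this read-out.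

Compound 3 `CCC[C@H](CO)NC(=O)c1cnc(Oc2ccc3c(c2C)B(O)OC3)cn1` has not yet been measured in this assay. Its difference from compound 2 is 1-(hydroxymethyl)butyl in place of 1-(hydroxymethyl)ethyl on an amide-type nitrogen.

Among the compounds with values here, only one measured step bears on this change: a 1.1-fold lower number from compound 1 to compound 2 (0.05 log units; within the scatter). It also reshaped the saturated chain on the amide-type nitrogen, and it stayed within the scatter. Within the data shown here, the present step lengthens that chain further, from 1-(hydroxymethyl)ethyl to 1-(hydroxymethyl)butyl, but no measured pair goes beyond a single methyl, so the expectation rests on that one step alone. No change beyond the scatter is expected in this assay, the estimated step being a 1.1-fold lower number from compound 2 to compound 3 (0.03 log units; within the scatter). Compound 3 is therefore expected to give about 2.5 h in this assay, with a range from 1.3 h to 5 h.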

Compound 3, half-life: 4.5 h
For compound 3 the middle estimate is 1.8-fold (0.26 log units) below the measured one; the range from low to high includes it.
By their numbers in this assay, from the lowest: compounds 2, 1 and 3 (each within the scatter of the next).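

Working notes on the chain on the amide-type nitrogen: in this assay, 1-(hydroxymethyl)butyl in place of 1-(hydroxymethyl)ethyl gives a 1.7-fold higher number from compound 2 to compound 3 (0.22 log units; within the scatter) and the same group measured against the unbranched chain of compound 1 gives a 1.5-fold higher number from compound 1 to compound 3 (0.18 log units; within the scatter) as the second reading of this position. The earlier pair covered a single added methyl only, whereas these steps extend the reading to a propyl on the saturated chain carbon, and all three compounds still stand as one on this read-out, so this position accepts the larger group with no shift in half-life beyond the scatter. No supporting data bear on why the numbers fall as they do.

The entering group carries a defined stereocentre, and the compounds shown give no reading of its mirror-image form, so the role of configuration at this carbon stays open. Also open, going by these compounds, is whether a longer chain, a ring such as cyclopropyl on this carbon, or an amine or carboxylic acid at the chain end would stay within the scatter of these three compounds.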